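Swapping an amine on two cores, one step at a time

The source may report more compounds than this note shows. Statements on the series, on what has been measured and on what is new or still open speak of the compounds shown alone.

Compound 1, `CCNCC(=O)Nc1cc(OC)ccc1C(=O)c1cc(OC)c(OC)c(OC)c1`, is tested in a functional assay on A2780 cells (Homo sapiens) for antiproliferative activity, read by MTT assay, with a stated time of 48 h (on this read-out higher numbers stand for weaker inhibition and lower numbers for stronger inhibition), and gives 950 nM. Compound 2, `COc1ccc(C(=O)c2cc(OC)c(OC)c(OC)c2)c(NC(=O)CN(C)C)c1`, carries a single change from compound 1, (dimethylamino in place of ethylamino on a saturated chain carbon bound to a carbonyl carbon); in this assay compound 2 gives 580 nM, so that a 1.6-fold lower number from compound 1 to compound 2 (0.21 log units; within the scatter). Compound 3, `C=C(c1ccc2c(c1)C=CC(C)(C)O2)c1ccc(OC)cc1NC(=O)CNCC`, is built on a different core, and the difference between the two cores is not broken down here. In this assay compound 3 gives 1870 nM; the gap to compound 1 lies within the scatter, the gap to compound 2 lies beyond it.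

Compound 4, `C=C(c1ccc2c(c1)C=CC(C)(C)O2)c1ccc(OC)cc1NC(=O)CN(C)C`, has not yet been measured. It differs from compound 3 by dimethylamino in place of ethylamino on a saturated chain carbon bound to a carbonyl carbon, the same change that separates compound 2 from compound 1, made at the same place. Among the measured compounds shown here, the only measured instance of this change moved the number a little and no more, so compound 4 is expected to land close to compound 3, leaning slightly toward a lower number. The step expected here is a 1.6-fold lower number from compound 3 to compound 4 (0.19 log units; within the scatter), which rests on the earlier pair because a 1.6-fold lower number from compound 1 to compound 2 (0.21 log units; within the scatter). That single instance was measured on another core, so the range is kept wide. Compound 4 is therefore estimated at 1200 nM in this assay, with a likely span from 500 nM to 3000 nM.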

Compound 4, half-maximal inhibitory concentration: 510 nM
Beside the measured number, compound 4's estimate is 2.4-fold (0.37 log units) above it; the measured number falls inside the stated range.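

On the core of compound 3, putting dimethylamino in place of ethylamino gives a 3.7-fold lower number from compound 3 to compound 4 (0.56 log units; beyond the scatter) in this assay, a step that clears the usual scatter of repeated measurements, whereas the same swap on the core of compound 1 stays within that scatter. Among the compounds shown here, it would be tempting to conclude that the change works better on one core than on the other, but the two steps are no further apart than two such steps can be by scatter alone, so the change can be said to carry over from one core to the other with no measurable difference in size: the same change on two cores in this assay, a 1.6-fold lower number (0.21 log units; within the scatter) from compound 1 to compound 2 and a 3.7-fold lower number (0.56 log units; beyond the scatter) from compound 3 to compound 4, 2.2-fold (0.35 log units) apart, within the scatter of two such steps This does not prove that the two steps are truly equal, and with only two pairs it gives no rule for what the same swap would do on any further core.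

The compounds shown leave open how other amines would behave at this place on the saturated chain carbon bound to the carbonyl carbon, such as a plain primary amine, diethylamino or a cyclic amine like pyrrolidine. They also leave open whether a longer chain carrying the amine would keep or lose the activity seen on either core.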